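Swapping Fluoro for Chloro on Compound 3

The source may hold more compounds than are shown below. What is called first, only, known or untested is meant among the compounds shown, and "the series" means these compounds.

In a functional assay on MDA-MB-231 cells (Homo sapiens) for inhibition, read by MTT assay, with a stated time of 5 days (on this read-out lower numbers stand for stronger inhibition and higher numbers for weaker inhibition), compound 1 `Cc1cc(Nc2nc(NCc3ccccc3Br)nc3[nH]ncc23)n[nH]1` gives 3990 nM, compound 2 `Cc1cc(Nc2nc(NCc3cccc(Cl)c3)nc3[nH]ncc23)n[nH]1` gives 6860 nM and compound 3 `Cc1cc(Nc2nc(NCc3ccc(F)cc3)nc3[nH]ncc23)n[nH]1` gives 8410 nM. Two steps place compound 3: a 1.2-fold higher number from compound 2 to compound 3 (0.09 log units; within the scatter), and a 2.1-fold higher number from compound 1 to compound 3 (0.32 log units; beyond the scatter). Compound 4 `Cc1cc(Nc2nc(NCc3ccc(Cl)cc3)nc3[nH]ncc23)n[nH]1` differs from compound 3 by one atom, with chloro in place of fluoro on an aromatic carbon. For the measured compounds named here, no measured step makes exactly this swap. The closest is a 1.2-fold higher number from compound 2 to compound 3 (0.09 log units; within the scatter), where 4-fluorophenyl replaces 3-chlorophenyl, and it stays within the scatter. No step beyond the scatter is therefore expected in this assay. The estimated step is a 1.2-fold lower number from compound 3 to compound 4 (0.08 log units; within the scatter). For compound 4 the estimated value is 7000 nM, with an expected range of 3700 nM to 13000 nM.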

Compound 4, half-maximal inhibitory concentration: 7500 nM
The estimate for compound 4 lay 1.1-fold (0.03 log units) below the measured number, within the range that was stated.
By their numbers in this assay, from the lowest: compounds 1, 2, 4 and 3 (each within the scatter of the next, the first and the last beyond it).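

In this assay, exchanging fluoro for chloro on an aromatic carbon, para to a large group, gives a 1.1-fold lower number from compound 3 to compound 4 (0.05 log units; within the scatter), so these two atoms cannot be told apart at this position. The 4-chlorophenyl group is also not separated from the 3-chlorophenyl group, with a 1.1-fold higher number from compound 2 to compound 4 (0.04 log units; within the scatter), or from the 2-bromophenyl group, with a 1.9-fold higher number from compound 1 to compound 4 (0.27 log units; within the scatter). Nothing available explains why these steps are so small. The compounds shown carry only halogens on this ring, so it remains open whether an amine or a carboxylic acid at this position would shift the number beyond the scatter.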